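This account rests on a few compounds, and the source may have more. Where it says the series, first, only, none or still open, it means among the compounds named here.

Compound 3 `O=c1[nH]c2ccc(-n3cc(C[C@H](O)COCCOC[C@@H](O)Cc4ccc(-c5ccccc5)cc4)nn3)cc2s1` gives the lowest of the two numbers shown here in a functional assay on HCT-116 cells (Homo sapiens) for inhibition, read by MTT assay, with a stated time of 72 h; on this read-out lower numbers stand for stronger inhibition of growth and higher numbers for weaker inhibition of growth: compound 3 gives 9200 nM. Its nearest neighbour is compound 1 `O[C@H](COCCOC[C@@H](O)Cc1cn(-c2cccs2)nn1)Cc1ccc(-c2ccccc2)cc1`, which in this assay gives 33400 nM; the move a 3.6-fold lower number from compound 1 to compound 3 (0.56 log units; beyond the scatter). Compound 2 `O[C@H](COCCOC[C@@H](O)Cc1cn(-c2cncnc2)nn1)Cc1ccc(-c2ccccc2)cc1` returns only a limit in this assay, > 100000 nM, which is the limit (the limit of > 100000 nM in this assay, at which 1 of the 3 values shown sits). From there the move an at least 10-fold lower number from compound 2 to compound 3 (1.03 log units; beyond the scatter), and in the other direction an at least 2.9-fold higher number from compound 1 to compound 2 (0.47 log units; beyond the scatter).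

Compound 4 `O[C@H](COCCOC[C@@H](O)Cc1cn(-c2cncc3ccccc23)nn1)Cc1ccc(-c2ccccc2)cc1` is the next step from compound 3: the change is a group of 10 heavy atoms (9 carbon, 1 nitrogen; one six-membered aromatic ring of carbon only, one six-membered aromatic ring with 1 hetero atom) in place of a group of 10 heavy atoms (7 carbon, 1 nitrogen, 1 oxygen, 1 sulfur; one five-membered aromatic ring with 2 hetero atoms, one six-membered aromatic ring of carbon only), on an aromatic nitrogen. Among the measured compounds shown here, the steps that bear on this position show that the two smaller single-ring groups on the aromatic nitrogen gave weaker inhibition of growth than the larger two-ring group of compound 3, with the pyrimidin-5-yl group of compound 2 only reaching the limit. The isoquinolin-4-yl group of compound 4 keeps two rings but loses the hydrogen-bond donor counted in the group that leaves. The expectation is therefore for a modest step to weaker inhibition, a 2.2-fold higher number from compound 3 to compound 4 (0.34 log units; beyond the scatter), with compound 4 estimated at 20000 nM in this assay, in a range from 6000 nM to 70000 nM.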

Compound 4, concentration for 50% growth inhibition: 17800 nM
Compound 4: the middle estimate sits 1.1-fold (0.05 log units) above what was measured, and the stated range covers the measured number.
By their numbers in this assay, from the lowest: compounds 3, 4 and 1 (each within the scatter of the next, the first and the last beyond it). At a limit, above all of these: compound 2.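

Replacing the two-ring group of compound 3 with isoquinolin-4-yl, which counts 0 hydrogen-bond donors, leaves the two compounds within the scatter of each other in this assay: a 1.9-fold higher number from compound 3 to compound 4 (0.29 log units; within the scatter), so among this pair a hydrogen-bond donor on this group is not needed to hold the number. A second ring is not a general gain over a single ring, and compound 4 goes against any such pattern: isoquinolin-4-yl does not separate from thiophen-2-yl, a 1.9-fold lower number from compound 1 to compound 4 (0.27 log units; within the scatter), although it does separate from pyrimidin-5-yl, an at least 5.6-fold lower number from compound 2 to compound 4 (0.74 log units; beyond the scatter). That last step gives only a minimum size, since compound 2 reaches only a limit: the limit of > 100000 nM in this assay, at which 1 of the 4 values shown sits.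

Every group shown on this aromatic nitrogen is an aromatic ring, so it remains open how an amine, a carboxylic acid or a longer open carbon chain would read there. Also open, from the compounds shown here alone, is what the ring nitrogen of isoquinolin-4-yl contributes, a question that a naphthyl group, with carbon in its place, would address.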